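A Nitro Group Replaces Methyl on the Sulfonyl Ring

The source may report more compounds than this note shows. Statements on the series, on what has been measured and on what is new or still open speak of the compounds shown alone.

Compound 1 `O=C1/C(=C/c2cccnc2)CN(S(=O)(=O)c2ccccc2)C/C1=C\c1ccccc1C(F)(F)F`: 6240 nM
Compound 2 `Cc1ccc(S(=O)(=O)N2C/C(=C\c3cccnc3)C(=O)/C(=C/c3ccccc3C(F)(F)F)C2)cc1`: 6170 nM

In a functional assay on QGY-7703 cells (Homo sapiens) for cytotoxicity, read by MTT assay, with a stated time of 24 h (on this read-out higher numbers stand for weaker inhibition and lower numbers for stronger inhibition), compound 2 gives 6170 nM, which cannot be told apart from compound 1. The two values lie within the usual scatter of repeat measurements. The next structure is compound 3 `O=C1/C(=C/c2cccnc2)CN(S(=O)(=O)c2ccc([N+](=O)[O-])cc2)C/C1=C\c1ccccc1C(F)(F)F`. It keeps the shared core of compound 2 and changes (4-methylphenyl)sulfonyl to (4-nitrophenyl)sulfonyl, which puts nitro in place of methyl on an aromatic carbon.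

Going by the values given here, only one measured step bears on this carbon, and it is a 1.0-fold lower number from compound 1 to compound 2 (0.00 log units; within the scatter). That step put methyl in place of hydrogen and stayed within the scatter. Among the compounds with values here, no measured compound here carries a nitro group, so the evidence is thin and the range must stay wide. On this single step, no change beyond the scatter is expected in this assay. The expected step is a 1.1-fold lower number from compound 2 to compound 3 (0.03 log units; within the scatter). Compound 3 is estimated at 5800 nM, with an expected range from 2500 nM to 13000 nM.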

Compound 3, half-maximal inhibitory concentration: 7660 nM
The estimate for compound 3 lay 1.3-fold (0.12 log units) below the measured number, and the stated range covers the measured number.
By their numbers in this assay, from the lowest: compounds 2, 1 and 3 (each within the scatter of the next).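

Placing nitro on this aromatic carbon gives, in this assay, a 1.2-fold higher number from compound 2 to compound 3 (0.09 log units; within the scatter), and starting from hydrogen instead of methyl it gives a 1.2-fold higher number from compound 1 to compound 3 (0.09 log units; within the scatter). Hydrogen, methyl and nitro at this carbon therefore cannot be told apart in this assay, even though nitro has more heavy atoms than methyl and adds hydrogen-bond acceptors that methyl lacks. The result thus extends the earlier comparison of hydrogen and methyl to a third group of a different make-up, but no measurement of any other property of these compounds accompanies it, and the flat result stays a bare observation.

From the compounds shown here alone, whether this carbon would stay equally flat with an amine, a carboxylic acid or a longer chain remains open, since three groups are too few to show how far the pattern reaches. These compounds also differ only at this one carbon, leaving unknown how changes elsewhere on the shared core would affect the number in this cell assay.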